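The compounds below may be only part of what the source reports. "The series", "measured", "known", "first", "only" and "open" are said of these compounds alone.

In an in vitro functional assay on cells for antagonist activity at B1 bradykinin receptor (Homo sapiens), read by luminescence and calcium flux, with a stated time of 2 h (on this read-out higher numbers stand for weaker inhibition and lower numbers for stronger inhibition), the measured members of the series stand as follows:

compound 1 `Cc1ccc(S(=O)(=O)N2C=CNC(=O)[C@H]2CC(=O)N[C@H]2CCN(C)CC2(C)C)cc1`: 0.42 nM
compound 2 `Cc1ccc(S(=O)(=O)N2C=CNC(=O)[C@H]2CC(=O)N[C@H]2CCN(CC(C)C)CC2(C)C)cc1`: 0.86 nM
compound 3 `Cc1ccc(S(=O)(=O)N2C=CNC(=O)[C@H]2CC(=O)N[C@H]2CCN(CC(C)(C)C)CC2(C)C)cc1`: 1.38 nM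

Compound 3 gives the highest of the three numbers: a 3.3-fold higher number from compound 1 to compound 3 (0.52 log units; beyond the scatter), whereas a 1.6-fold higher number from compound 2 to compound 3 (0.21 log units; within the scatter). The next compound, compound 4 `Cc1ccc(S(=O)(=O)N2C=CNC(=O)[C@H]2CC(=O)N[C@H]2CCN(C3CCC3)CC2(C)C)cc1`, carries cyclobutyl in place of neopentyl on an amine nitrogen in a ring. Among the measured compounds shown here, the steps that bear on this change are those on the same nitrogen: a 2.0-fold higher number from compound 1 to compound 2 (0.31 log units; beyond the scatter) and a 3.3-fold higher number from compound 1 to compound 3 (0.52 log units; beyond the scatter), both modest rises as the group grew, while a 1.6-fold higher number from compound 2 to compound 3 (0.21 log units; within the scatter) added little. Cyclobutyl brings one heavy atom fewer than neopentyl and a ring, so the change runs back toward the smaller groups of compound 2 and compound 1 but with no direct precedent. A number near that of compound 2 is therefore expected for compound 4, which means a small downward step, a 1.6-fold lower number from compound 3 to compound 4 (0.21 log units; within the scatter), likely within the scatter. The estimate for compound 4 in this assay is 0.85 nM, with a range of 0.35 nM to 2 nM.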

Compound 4, half-maximal inhibitory concentration: 0.74 nM
Compound 4: the middle estimate sits 1.1-fold (0.06 log units) above what was measured; the measured number falls inside the stated range.
By their numbers in this assay, from the lowest: compounds 1, 4, 2 and 3 (each within the scatter of the next, the first and the last beyond it).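

In this assay, among the compounds shown here, cyclobutyl is the only ring group on this amine nitrogen among the four compounds, and it stays within the scatter of all three open-chain groups: a 1.9-fold lower number from compound 3 to compound 4 (0.27 log units; within the scatter), a 1.2-fold lower number from compound 2 to compound 4 (0.07 log units; within the scatter) and a 1.8-fold higher number from compound 1 to compound 4 (0.25 log units; within the scatter). The nitrogen therefore accepts a four-membered carbon ring with no step beyond the scatter, and compound 4 has no such step to any compound shown, whereas the pair compound 1 and compound 3 remains separated beyond it. Nothing available accounts for this result.

As far as these compounds go, it remains open whether a larger ring such as cyclohexyl, or an oxygen-containing ring such as tetrahydropyranyl, would stay in the same range on this nitrogen. The effect of a plain hydrogen there is also unresolved.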